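The compounds below may be only part of what the source reports. "The series", "measured", "known", "first", "only" and "open" are said of these compounds alone.

Series notes. Compound 1 `CC(C)(C)OC(=O)N1CCC(c2coc3c(N4CCc5cc(S(C)(=O)=O)ccc54)ncnc23)CC1` carries a tert-butoxycarbonyl on the ring amine; in a functional assay on cells for agonist activity at Glucose-dependent insulinotropic receptor (Homo sapiens), read by a luciferase reporter, with a stated time of 4 h (a higher number here means that more compound is needed for the effect, a lower number that less compound is needed), compound 1 gives 53 nM. Among the compounds with values here, compound 2 `CS(=O)(=O)c1ccc2c(c1)CCN2c1ncnc2c(C3CCN(c4ncc(F)cn4)CC3)coc12` carries a 5-fluoropyrimidin-2-yl in that place; in this assay compound 2 gives 201 nM, the highest of the two numbers so far, reached by a 3.8-fold higher number from compound 1 to compound 2 (0.58 log units; beyond the scatter), a modest step.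

Compound 3 `COc1cnc(N2CCC(c3coc4c(N5CCc6cc(S(C)(=O)=O)ccc65)ncnc34)CC2)nc1` is reached by a single change on the pyrimidine: methoxy in place of fluoro on an aromatic carbon. Within the data shown here, no measured step bears on this exchange; the only step in hand, a 3.8-fold higher number from compound 1 to compound 2 (0.58 log units; beyond the scatter), swaps the whole group on the ring amine and says nothing about a substituent on the pyrimidine. Among the measured compounds shown here, with no precedent, no step beyond the scatter is expected in either direction in this assay; the expected step is a 1.0-fold lower number from compound 2 to compound 3 (0.00 log units; within the scatter). For compound 3 the estimated value in this assay is 200 nM, with a range of 80 nM to 500 nM.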

Compound 3, half-maximal effective concentration: 310 nM
Beside the measured number, compound 3's estimate is 1.6-fold (0.19 log units) below it, and the stated range covers the measured number.
By their numbers in this assay, from the lowest: compound 1; then compounds 2 and 3 (each within the scatter of the next).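

Within the data shown here, this is the first reading at this carbon of the pyrimidine, which sits para to a large group: methoxy in place of fluoro gives a 1.5-fold higher number from compound 2 to compound 3 (0.19 log units; within the scatter) in this assay, so the two groups cannot be told apart here. The pyrimidine in place of tert-butoxycarbonyl on the ring amine now has a second reading, a 5.8-fold higher number from compound 1 to compound 3 (0.77 log units; beyond the scatter), and both pyrimidine compounds stand beyond the scatter from compound 1, so the earlier step does not hang on fluoro alone. Nothing in hand explains either step.

Two substituents on one carbon say little about the range of this position, and an amine or a nitrile there could still move the number beyond the scatter. Going by these compounds, whether any group on the pyrimidine brings the number back to that of compound 1 remains open.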